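The source may report more compounds than this note shows. Statements on the series, on what has been measured and on what is new or still open speak of the compounds shown alone.

In a physicochemical assay for solubility, read by chemiluminescence, measured as kinetic solubility (a higher number here means a more soluble compound, a lower number a less soluble compound), compound 1 `COc1nn(C)c2ncnc(NS(=O)(=O)c3cccc(Cl)c3Cl)c12` gives >= 581000 nM, which is a limit and not a number. Compound 2 `COc1nn(C)c2nc(NC3COC3)nc(NS(=O)(=O)c3cccc(Cl)c3Cl)c12` gives >= 712000 nM, and this too is a limit. For the measured compounds named here, the only measured step is a step that the two limits leave unreadable from compound 1 to compound 2. It brings in (oxetan-3-yl)amino and leaves the group on the sulfonyl sulfur untouched, so it offers no size or direction for the change considered here. Compound 3 `COc1nn(C)c2ncnc(NS(=O)(=O)c3ccc(Cl)s3)c12` keeps the core of compound 1 and carries 5-chlorothiophen-2-yl in place of 2,3-dichlorophenyl on a sulfonyl sulfur. Going by the values given here, no measured step bears on this exchange, so no shift beyond the scatter is expected in this assay. The expected change is a step that the limit leaves unreadable from compound 1 to compound 3. For compound 3 the estimated value is 600000 nM, with an expected range from 250000 nM to 900000 nM.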

Compound 3, solubility: >= 538000 nM
Compound 3 was reported as a limit (the forecaster's own chance of this, stated with the estimate: 60%); the middle value does not contradict the limit.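

In this assay, compound 1 and compound 3 both stand only as limits, and no new step can be read between them. The compounds shown leave open whether 5-chlorothiophen-2-yl in place of 2,3-dichlorophenyl on a sulfonyl sulfur changes solubility at all, and in which direction.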